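Aryl to propyl at the aromatic nitrogen: compound 4

The source may report more compounds than this note shows. Statements on the series, on what has been measured and on what is new or still open speak of the compounds shown alone.

compound 1 `Cc1ccccc1Cn1c(CN2CCN(C(=O)C3CC3)CC2)nc2ccccc21` — 29.1%
compound 2 `COc1cccc(Cn2c(CN3CCN(C(=O)C4CC4)CC3)nc3ccccc32)c1` — 44.4%
compound 3 `O=C(C1CC1)N1CCN(Cc2nc3ccccc3n2Cc2ccc(C(F)(F)F)cc2)CC1` — 37%

In an assay on isolated protein for inhibition of aldehyde dehydrogenase 1A1 (Homo sapiens), read by spectrophotometry, tested at 10 uM (on this read-out higher numbers stand for more inhibition at the one concentration tested (going by the name of the read-out) and lower numbers for less inhibition), compound 3 gives 37%, the second highest of the three numbers; its steps to both neighbours stay within the scatter: a number 7.4 percentage points lower from compound 2 to compound 3 (within the scatter) and a number 7.9 percentage points higher from compound 1 to compound 3 (within the scatter). Only a number 15.3 percentage points higher from compound 1 to compound 2 (beyond the scatter) goes beyond the scatter. Compound 4 `CCCCn1c(CN2CCN(C(=O)C3CC3)CC2)nc2ccccc21` differs from compound 3 by propyl in place of 4-(trifluoromethyl)phenyl on a saturated chain carbon bound to an aromatic nitrogen. Every measured step exchanges one substituted phenyl for another at this place; none removes the aromatic ring, so the measured steps bear only loosely on this change. For the measured compounds named here, with the aryl swaps staying small, no measured step supports a large move; compound 4 is expected at 25% (range 10% to 42%). The expected step is a number 12 percentage points lower from compound 3 to compound 4 (beyond the scatter), downward but near the scatter.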

Compound 4, a percentage reported as inhibition, at one concentration (the size of the read-out at that concentration, not a potency): 18.2%
Beside the measured number, compound 4's estimate is 6.8 percentage points above it, within the range that was stated.
By their numbers in this assay, from the lowest: compound 4; then compounds 1, 3 and 2 (each within the scatter of the next, the first and the last beyond it).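

Propyl in place of each substituted phenyl at this place, on a saturated chain carbon bound to an aromatic nitrogen, gives a number 18.8 percentage points lower from compound 3 to compound 4 (beyond the scatter) and a number 26.2 percentage points lower from compound 2 to compound 4 (beyond the scatter) and also a number 10.9 percentage points lower from compound 1 to compound 4 (beyond the scatter) as the steps, all beyond the scatter. Compound 4 therefore stands as the lowest of the four, and in these compounds all three aromatic groups give more inhibition than the open chain. The size of the loss still depends on which phenyl leaves.

Open, on these data alone, is whether a longer chain, or a chain ending in an amine or a carboxylic acid, would recover the loss. Nothing available gives a reason for the drop at this place.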